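The source may report more compounds than this note shows. Statements on the series, on what has been measured and on what is new or still open speak of the compounds shown alone.

Within the data shown here, compound 2 (`COc1cc(OC)cc(C(=O)/N=C(/NC(=O)c2cc(OC)cc(OC)c2)[Se]C)c1`) is the one measured compound in this set that gives a number rather than a limit. In a functional assay on PC-3 cells (Homo sapiens) for cytotoxicity, read by MTT assay (on this read-out higher numbers stand for weaker inhibition and lower numbers for stronger inhibition), compound 2 gives 6500 nM. Compound 1 (`CC(C)[Se]/C(=N\C(=O)c1ccccc1)NC(=O)c1ccccc1`) is the other measured compound, and in this assay compound 1 gives only a limit, > 10000 nM; this is the limit of > 10000 nM in this assay, at which 1 of the 2 values shown sits. Among the measured compounds shown here, the two compounds differ in more than one place, so the two values show only that compound 1 sits at the limit while compound 2 lies within range.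

Compound 3 (`COc1cc(OC)cc(C(=O)/N=C(/NC(=O)c2cc(OC)cc(OC)c2)[Se]C(C)C)c1`) differs from compound 2 in a single place: isopropyl in place of methyl on a selenium. For the measured compounds named here, no step between measured compounds is known, so the step is expected to be modest, within or only slightly beyond the usual scatter, leaning toward weaker inhibition. Compound 3 is estimated at 9000 nM, between 3000 nM and 30000 nM, a step from compound 2 to compound 3 of a 1.4-fold higher number from compound 2 to compound 3 (0.14 log units; within the scatter) that is expected rather than measured.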

Compound 3, half-maximal inhibitory concentration: > 10000 nM
Compound 3: only a limit was reported (the forecaster's own chance of this, stated with the estimate: 40%); middle value at least 1.1-fold (0.04 log units) from the limit.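

In this assay, among these compounds, isopropyl in place of methyl on a selenium gives an at least 1.5-fold higher number from compound 2 to compound 3 (0.18 log units; that floor lies within the scatter), the first reading in this set of a change made in one place alone. It shows that this larger group does not bring the compound into measurable range, while the methyl of compound 2 does give a number. From the compounds shown here alone, the step is only a floor, and its true size stays unknown, because the value of compound 3 is a limit: the limit of > 10000 nM in this assay, at which 2 of the 3 values shown sit.

The compounds shown leave open how other groups on this selenium would behave, such as ethyl, a longer chain or benzyl, and whether any would give a lower number than compound 2, at 6500 nM. Also open, going by these compounds, is what an amine or a carboxylic acid on such a chain would do.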